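Working notes on cytotoxicity across the series

The compounds below may be only part of what the source reports. "The series", "measured", "known", "first", "only" and "open" are said of these compounds alone.

Within the data shown here, in an ADME assay on cells (Homo sapiens) for cytotoxicity, read by resazurin assay, with a stated time of 5 days (a higher number here means that more compound is tolerated, a lower number that less compound is tolerated), compound 2 `O=S(=O)(Cc1nc(-c2ccnc(Cl)c2)c2sccc2n1)c1cccc(Cl)c1` gives 63000 nM, the only number among the three measured compounds. Compound 1 `COc1ccc(-c2nc(C(C)S(=O)(=O)c3cccc(Cl)c3)nc3ccsc23)cn1` reaches only a limit, > 50000 nM, namely (the limit of > 50000 nM in this assay, at which 1 of the 3 values shown sits). Compound 3 `COc1ccc(-c2nc(CSc3cccc(Cl)c3)nc3ccsc23)cn1` likewise stops at a limit, > 10000 nM, which is the limit of > 10000 nM in this assay, at which 1 of the 3 values shown sits. Compound 2 therefore stands alone as a numerical value, with nothing that places it above or below the others. Compound 4 `COc1ccc(Oc2nc(CS(=O)(=O)c3cccc(Cl)c3)nc3ccsc23)cc1` differs from compound 2 by 4-methoxyphenoxy in place of 2-chloropyridin-4-yl on an aromatic carbon. Among the measured compounds shown here, no measured step in this assay accompanies such a change, so no direction can be drawn from the series, and no shift beyond the scatter is expected in this assay. Compound 4 is thus expected near 60000 nM, within 20000 nM to 150000 nM. The expected step of a 1.1-fold lower number from compound 2 to compound 4 (0.02 log units; within the scatter) is estimated to sit within the scatter.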

Compound 4, half-maximal cytotoxic concentration: > 50000 nM
Compound 4: only a limit was reported (the forecaster's own chance of this, stated with the estimate: 60%); the middle value is on the limit's open side.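

No step from compound 2 to compound 4 can be read, because compound 4 gives only a limit: the limit of > 50000 nM in this assay, at which 2 of the 4 values shown sit.

The compounds shown leave open whether 4-methoxyphenoxy in place of 2-chloropyridin-4-yl changes the tolerated concentration at all.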